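Moving the nitro group on the pyrazoline aryl ring

This account rests on a few compounds, and the source may have more. Where it says the series, first, only, none or still open, it means among the compounds named here.

Measured compounds:
compound 1 `CC(=O)N1N=C(c2cccc3ccccc23)CC1c1cccc(Br)c1` — 12000 nM
compound 2 `O=CCN1N=C(c2ccc3ccccc3c2)CC1c1ccccc1` — 7400 nM
compound 3 `O=CCN1N=C(c2ccc3ccccc3c2)CC1c1cccc([N+](=O)[O-])c1` — 2980 nM

In a functional assay on PC-3 cells (Homo sapiens) for cytotoxicity, read by sulforhodamine B assay, with a stated time of 48 h (on this read-out higher numbers stand for weaker inhibition and lower numbers for stronger inhibition), compound 3 gives 2980 nM, the lowest number of the three. Its nearest neighbour is compound 2 with 7400 nM, and the furthest is compound 1 with 12000 nM. Among the measured compounds shown here, the one single-change step among the measured compounds runs a 2.5-fold lower number from compound 2 to compound 3 (0.40 log units; beyond the scatter), so placing a nitro group on the pendant aromatic ring, where there was hydrogen, brought a modest gain beyond the scatter.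

Compound 4 `O=CCN1N=C(c2ccc3ccccc3c2)CC1c1ccccc1[N+](=O)[O-]` is built from compound 3 by the change (2-nitrophenyl in place of 3-nitrophenyl on a saturated ring carbon). For the measured compounds named here, no measured step in this assay touches the position of a substituent on that ring, so nothing in the data says how moving the nitro group from one ring carbon to another will turn out. The step from compound 2 to compound 3 only shows that a nitro group on this ring is tolerated and helpful in one position. With that alone as footing, the expectation for compound 4 is a step of about a 1.5-fold higher number from compound 3 to compound 4 (0.18 log units; within the scatter) relative to compound 3, which is to say no clear movement beyond the scatter, with a wide band in either direction. Compound 4 is therefore estimated at 4500 nM, in a range from 1500 nM to 13000 nM.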

Compound 4, half-maximal inhibitory concentration: 3010 nM
Compound 4: the middle estimate sits 1.5-fold (0.17 log units) above what was measured; the measured number falls inside the stated range.
By their numbers in this assay, from the lowest: compounds 3 and 4 (each within the scatter of the next); then compounds 2 and 1 (each within the scatter of the next).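

In this assay, the exchange of 3-nitrophenyl for 2-nitrophenyl gives a 1.0-fold higher number from compound 3 to compound 4 (0.00 log units; within the scatter), so this read-out does not separate the two placings of the nitro group on this ring. The nitro group in place of hydrogen can now be read twice, as a 2.5-fold lower number from compound 2 to compound 3 (0.40 log units; beyond the scatter) and as a 2.5-fold lower number from compound 2 to compound 4 (0.39 log units; beyond the scatter), each beyond the scatter, which shows that the modest gain first seen with 3-nitrophenyl is not confined to that one arrangement and also appears with 2-nitrophenyl. Nothing at hand offers an independent measurement that would explain why the two isomers read alike.

The compounds shown contain no group other than nitro on this ring in either placing, so it remains open whether an amine, a carboxylic acid or a methoxy group would match the nitro group or would instead respond to the change of ring carbon. Going by these compounds, it also remains open whether the equal readings of the two nitro isomers would hold if a longer chain stood in place of the formylmethyl group.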